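This account rests on a few compounds, and the source may have more. Where it says the series, first, only, none or still open, it means among the compounds named here.

Of the compounds shown here, two carry a measured value so far. Compound 2 `COc1nc(-c2nc3ccccc3n2C)cc(-c2ccc(Cl)cc2Cl)c1C#N` in a functional assay on aorta (Rattus norvegicus, strain Wister) (on this read-out lower numbers stand for stronger inhibition and higher numbers for weaker inhibition), gives 214000 nM. Compound 1 `CCOc1nc(-c2nc3ccccc3n2C)cc(-c2ccc(Cl)cc2)c1C#N` in this assay gives 293000 nM; the gap between compound 2 and compound 1 lies within the scatter of repeated measurements, so the two read as one level. Among the compounds with values here, compound 1 and compound 2 differ in two places at once, so no single step between measured compounds is available.

Compound 3 `CCOc1nc(-c2nc3ccccc3n2C)cc(-c2ccc(Cl)cc2Cl)c1C#N` is the next member, not yet measured in this assay. Relative to compound 2 the change is methyl in place of hydrogen on a saturated chain carbon bound to an oxygen on an aromatic ring, read one bond further out as methoxy to ethoxy. Within the data shown here, no measured pair isolates this change. Among the measured compounds shown here, with the two known numbers at one level, no step beyond the scatter is expected for a 1.1-fold higher number from compound 2 to compound 3 (0.05 log units; within the scatter). Compound 3 in this assay is therefore estimated at 240000 nM, with a range from 100000 nM to 550000 nM.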

Compound 3, half-maximal inhibitory concentration: 305000 nM
Estimate against measurement, compound 3: 1.3-fold (0.10 log units) below; the measured number falls inside the stated range.
By their numbers in this assay, from the lowest: compounds 2, 1 and 3 (each within the scatter of the next).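

The series now has single-place steps in this assay. Methyl in place of hydrogen on a saturated chain carbon bound to an oxygen on an aromatic ring, read as methoxy to ethoxy, gives a 1.4-fold higher number from compound 2 to compound 3 (0.15 log units; within the scatter), so this change does not separate the two compounds on this read-out. Chloro in place of hydrogen on an aromatic carbon gives a 1.0-fold higher number from compound 1 to compound 3 (0.02 log units; within the scatter), so that change does not separate its pair either, and no information bears on the reason for either result.

From the compounds shown here alone, whether a longer chain such as propoxy, or an amine on the saturated chain in place of the added methyl, would give a step beyond the scatter remains open. Also open, going by these compounds, is whether the chloro step reads the same with methoxy in place of ethoxy.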